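The compounds below may be only part of what the source reports. "The series", "measured", "known", "first", "only" and "open" are said of these compounds alone.

Three related compounds have been measured in an ADME assay on a cell-free system (plasma, Mus musculus) for protein binding; a higher number here means a larger unbound share of the compound, a lower number a smaller unbound share. Compound 1 `CC(C)COc1ncc(-c2cn(C)c3cc(C(=O)NS(C)(=O)=O)ccc23)cc1Cl` gives 0.002, compound 3 `CC(C)COc1ncc(-c2cn(C)c3cc(C(=O)NS(=O)(=O)C4CC4)c(F)cc23)cc1Cl` gives 0.002, and compound 2 `Cn1cc(-c2ccc(C(F)(F)F)cc2)c2cc(F)c(C(=O)NS(=O)(=O)C3CC3)cc21` gives 0.0035. The gaps from compound 2 to the other two lie within the usual scatter of repeated measurements, so these three numbers cannot be told apart.

Compound 4 `Cn1cc(-c2ccc(C(F)(F)F)cc2)c2ccc(C(=O)NS(=O)(=O)C3CC3)cc21` matches compound 2 except at one place: hydrogen in place of fluoro on an aromatic carbon. Hydrogen stands in place of fluoro on an aromatic carbon, ortho to the (cyclopropylsulfonyl)carbamoyl group. Within the data shown here, no measured pair isolates this swap, so the data give no direct guide to its size or direction. The expectation therefore starts from compound 2 at 0.0035, and no change beyond the scatter is expected in this assay. The estimated step of a 1.2-fold lower number from compound 2 to compound 4 (0.07 log units; within the scatter) stays within that scatter. Compound 4 is expected to give about 0.003, with an estimated range from 0.0015 to 0.006.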

Compound 4, unbound fraction: 0.004
The estimate for compound 4 lay 1.3-fold (0.12 log units) below the measured number, and the stated range covers the measured number.
By their numbers in this assay, from the lowest: compounds 1, 3, 2 and 4 (each within the scatter of the next).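

Swapping the fluoro for hydrogen on this aromatic carbon, ortho to the (cyclopropylsulfonyl)carbamoyl group, gives the only pair here that isolates a single change, and in this assay the step is a 1.1-fold higher number from compound 2 to compound 4 (0.06 log units; within the scatter). For this pair, then, the fluoro can be exchanged for hydrogen with no change that the assay can distinguish from repeat-measurement variation, although one pair cannot establish a general rule for this position. No supporting measurement is available to explain the result in terms of either group.

As far as these compounds go, whether a larger or different group on this carbon, such as a methoxy group, a nitrile or an amine, would move the unbound fraction remains open. From the compounds shown here alone, it is also open whether the same swap would behave alike on compound 3, which carries the same fluoro but differs elsewhere.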